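The source may hold more compounds than are shown below. What is called first, only, known or untested is meant among the compounds shown, and "the series" means these compounds.

Two compounds of the series carry numbers in an ADME assay on HEp-2 cells (Homo sapiens) for cytotoxicity, read by MTT assay, with a stated time of 60 h; on this read-out higher numbers stand for lower toxicity in this test and lower numbers for higher toxicity in this test. Compound 1 `Cc1ccc(S(=O)(=O)O[C@@H]2CO[C@H]3[C@@H]2OCc2nc4c(Br)c(C)c(Br)cc4n23)cc1` gives 8940 nM in this assay. Compound 2 `O[C@@H]1CO[C@H]2[C@@H]1OCc1nc3cc(Br)c(Br)cc3n12` gives 181000 nM in this assay. Compound 1 thus stands lowest of the two numbers; the gap to compound 2 lies beyond the scatter, so compound 1 is the more toxic of the two in this test. For the measured compounds named here, the two compounds differ in more than one place, so no single step between them is counted, and nothing is known about which of their differences carries the gap.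

Compound 3 `Cc1c(Br)cc2c(nc3n2[C@H]2OC[C@@H](OS(C)(=O)=O)[C@H]2OC3)c1Br` has not yet been measured in this assay. Against compound 1 it shows one change: methyl in place of 4-methylphenyl on a sulfonyl sulfur. Going by the values given here, no measured pair shows this change, so there is no step to lean on. With only the group on the sulfonyl sulfur exchanged, no shift beyond the scatter is expected, and the direction is left open. The step from compound 1 to compound 3 is expected at a 1.3-fold higher number from compound 1 to compound 3 (0.13 log units; within the scatter). Compound 3 is estimated at 12000 nM, with a range from 3500 nM to 45000 nM.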

Compound 3, half-maximal cytotoxic concentration: 15600 nM
Compound 3: the middle estimate sits 1.3-fold (0.11 log units) below what was measured; the measured number falls inside the stated range.
By their numbers in this assay, from the lowest: compounds 1 and 3 (each within the scatter of the next); then compound 2.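

On the sulfonyl sulfur, methyl in place of 4-methylphenyl gives a 1.7-fold higher number from compound 1 to compound 3 (0.24 log units; within the scatter) in this assay, so the two compounds cannot be told apart in this test. For the compounds shown here, this is the first single-place comparison, and it shows that a group of 7 heavy atoms with a six-membered aromatic ring can give way to a single carbon without a shift beyond the scatter; at this position, in this pair, the 4-methylphenyl ring is therefore not required for a number of this size. No measurement shown here offers an explanation for this result.

From the compounds shown here alone, a wider range of groups at this place remains open, such as a longer chain on the sulfonyl sulfur, or an amine or a carboxylic acid in place of the whole sulfonyl group on the core of compound 3. The gap to compound 2 also remains unassigned, as compound 2 differs from compound 1 and from compound 3 in more than one place.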